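The compounds below may be only part of what the source reports. "The series", "measured", "known", "first", "only" and "open" are said of these compounds alone.

Measured so far in a functional assay on HT-29 cells (Homo sapiens) for antiproliferative activity, read by sulforhodamine B assay, with a stated time of 48 h; on this read-out higher numbers stand for weaker inhibition and lower numbers for stronger inhibition:
compound 1 `CCc1ccccc1NS(=O)(=O)c1ccc(N2CCNC2=O)cc1`: 240 nM
compound 2 `Cc1ccccc1NS(=O)(=O)c1ccc(N2CCNC2=O)cc1`: 200 nM
compound 3 `O=C1NCCN1c1ccc(S(=O)(=O)Nc2cccc(Oc3ccccc3)c2)cc1`: 200 nM

Compound 3 stands level with compound 2 at the digits shown, the two together at the lowest number of the three; compound 1 sits a little higher, within the scatter, so the three compounds cannot be ordered on these numbers.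

Compound 4 `O=C1NCCN1c1ccc(S(=O)(=O)Nc2cccc(Cl)c2)cc1` differs from compound 3 by chloro in place of phenoxy on an aromatic carbon. For the measured compounds named here, the only measured step, a 1.2-fold lower number from compound 1 to compound 2 (0.08 log units; within the scatter), concerns a different position and a different kind of change, and was itself within the scatter; no measured step bears directly on this exchange. For compound 4 in this assay a step of a 1.5-fold higher number from compound 3 to compound 4 (0.18 log units; within the scatter) is therefore expected, no larger than the scatter, with the estimate for compound 4 at 300 nM and a range of 100 nM to 1000 nM.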

Compound 4, half-maximal inhibitory concentration: 55 nM
Compound 4: the middle estimate sits 5.5-fold (0.74 log units) above what was measured; measured number below the stated range.
By their numbers in this assay, from the lowest: compound 4; then compounds 2, 3 and 1 (each within the scatter of the next).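

Chloro in place of phenoxy, on an aromatic carbon meta to a large group, gives a 3.6-fold lower number from compound 3 to compound 4 (0.56 log units; beyond the scatter) and is the first exchange in the series to move the number beyond the scatter. As the whole group on the sulfonamide nitrogen, 3-chlorophenyl gives a 3.6-fold lower number from compound 2 to compound 4 (0.56 log units; beyond the scatter) from 2-methylphenyl and a 4.4-fold lower number from compound 1 to compound 4 (0.64 log units; beyond the scatter) from 2-ethylphenyl. Nothing available explains these steps.

The compounds shown leave open how an amine, a carboxylic acid or a methoxy group on this carbon would compare with chloro. Also open, as far as these compounds go, is whether chloro would give a similar number on another carbon of that ring.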